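Replacing hydroxy on a compound at the assay limit

A few compounds are considered here, and "the series" means these few. Any claim that something is new, unique, unknown or untested is made for them only; others in the source may bear on it.

In a functional assay on NCI-H1299 cells (Homo sapiens), read by flow cytometry (on this read-out higher numbers stand for an effect only at larger amounts of compound and lower numbers for an effect already at smaller amounts), compound 1 (`N#Cc1ncc2nc1OCC/C=C\COc1ccc(O)cc1NC(=O)N2`) gives > 10000 nM as a limit of the assay, not a number. Compound 2 (`COc1ccc2c(c1)NC(=O)Nc1cnc(C#N)c(n1)OCCCCCO2`) gives > 10000 nM as a limit too. Compound 3 (`N#Cc1ncc2nc1OCCCCCOc1ccc(Br)cc1NC(=O)N2`) gives 10000 nM as a number. The change leading to compound 4 (`N#Cc1ncc2nc1OCC/C=C\COc1ccc(CCOC3CCCCO3)cc1NC(=O)N2`) is 2-((oxan-2-yl)oxy)ethyl in place of hydroxy on an aromatic carbon and amounts to 2-((oxan-2-yl)oxy)ethyl in place of hydroxy on an aromatic carbon. Among the compounds with values here, the one measured step, a number no higher from compound 2 to compound 3 (the limit leaves the size open) with bromo in place of methoxy, is also a swap on an aromatic carbon, but its size stays open. Within the data shown here, compound 4 is expected to stay at the weak end because of the limit of > 10000 nM in this assay, at which 2 of the 3 values shown sit, and no measured step shows a gain. The expected step in this assay is a number no higher from compound 1 to compound 4 (the limit leaves the size open) and only a rough guess. Compound 4 is estimated at 10000 nM within a range of 3000 nM to 30000 nM on this scale.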

Compound 4, half-maximal effective concentration: > 10000 nM
Compound 4: a limit, no number; the forecaster's own chance of this, stated with the estimate: 70%; the middle value lies on the limit itself.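

Within the data shown here, compound 1 and compound 4 each give only a limit in this assay, not a number, so no step between them can be read. On these data alone, whether 2-((oxan-2-yl)oxy)ethyl in place of hydroxy changes the effect at all stays open.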